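From 4-bromophenyl to 3-bromophenyl in the series

The compounds below may be only part of what the source reports. "The series", "measured", "known", "first", "only" and "open" are said of these compounds alone.

Going by the values given here, in an ADME assay on SH-SY5Y cells (Homo sapiens) for cytotoxicity, read by MTT assay, with a stated time of 72 h (on this read-out lower numbers stand for stronger inhibition and higher numbers for weaker inhibition), compound 1 (`O=C(CN1CCN(C(=O)c2ccc(Br)cc2)CC1)N1CCN(CCCc2c[nH]c3ccccc23)CC1`) gives 59300 nM and compound 2 (`COc1ccc2[nH]cc(CCCN3CCN(C(=O)CN4CCN(C(=O)c5ccc(Br)cc5)CC4)CC3)c2c1`) gives 150000 nM as the higher of the two numbers so far. Among the compounds with values here, the only measured step is a 2.5-fold higher number from compound 1 to compound 2 (0.40 log units; beyond the scatter) for methoxy in place of hydrogen on an aromatic carbon, modest but beyond the scatter.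

Compound 3 (`COc1ccc2[nH]cc(CCCN3CCN(C(=O)CN4CCN(C(=O)c5cccc(Br)c5)CC4)CC3)c2c1`) differs from compound 2 by 3-bromophenyl in place of 4-bromophenyl on a carbonyl carbon and so carries 3-bromophenyl in place of 4-bromophenyl on a carbonyl carbon. Within the data shown here, the measured step concerns a different change, and no measured pair compares these two groups. In this assay no step beyond the scatter is therefore expected, and neither direction is favoured. The expected step is no change at the digits printed from compound 2 to compound 3 (within the scatter) as an estimate only. For compound 3 the estimated value is 150000 nM with an expected range from 70000 nM to 300000 nM on present data.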

Compound 3, half-maximal inhibitory concentration: 105000 nM
For compound 3 the middle estimate is 1.4-fold (0.15 log units) above the measured one; measured number inside the range.
By their numbers in this assay, from the lowest: compounds 1, 3 and 2 (each within the scatter of the next, the first and the last beyond it).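

In this assay, 3-bromophenyl in place of 4-bromophenyl on a carbonyl carbon gives a step that lies within the scatter (a 1.4-fold lower number from compound 2 to compound 3 (0.15 log units; within the scatter)), so this read-out does not separate the two bromophenyl groups at this position. The earlier step (a 2.5-fold higher number from compound 1 to compound 2 (0.40 log units; beyond the scatter)) concerned methoxy in place of hydrogen on an aromatic carbon, and only the new pair varies the group on the carbonyl carbon, with the same atoms joined differently. No measurement offered here bears on why the two groups read alike.

Still open, as far as these compounds go, is how a group without bromine, such as plain phenyl, or one carrying an amine or a carboxylic acid, would read on this carbonyl carbon. Also open, from the compounds shown here alone, is whether the methoxy step seen with 4-bromophenyl carries over to 3-bromophenyl.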